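This account rests on a few compounds, and the source may have more. Where it says the series, first, only, none or still open, it means among the compounds named here.

Compound 1 `COC(=O)Nc1cccc(-c2ccc(N(C)C)cc2)c1` and compound 2 `CN(C)c1ccc(-c2cccc(NC(=O)C(C)(C)C)c2)cc1` share one core and differ only in the group on the carbonyl carbon. In an assay on COS-7 cells for inhibition of patatin-like phospholipase domain-containing protein 2 (Mus musculus), tested at 200 uM (a lower number here means less inhibition, a higher number more inhibition at the concentration tested (going by the name of the read-out)), compound 1 gives 95%, whereas compound 2 gives 25%. Going by the values given here, the one measured step between them is a number 70 percentage points lower from compound 1 to compound 2 (beyond the scatter), and it leaves compound 2 with the lowest of the two numbers, its nearest neighbour being compound 1, which stands higher by that same step.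

Compound 3 `CCOC(=O)N(C)c1cccc(-c2ccc(N(C)C)cc2)c1` has not yet been measured. It differs from compound 2 by (ethoxycarbonyl)(methyl)amino in place of ((tert-butyl)carbonyl)amino on an aromatic carbon. The carbonyl carbon thus carries an alkoxy group again, as in compound 1, while the nitrogen now bears a methyl and no longer offers a hydrogen-bond donor. The step of a number 70 percentage points lower from compound 1 to compound 2 (beyond the scatter) bears directly on the carbonyl part of this change, and reversing it points toward a large recovery. Nothing measured speaks to the methyl on the nitrogen or to ethoxy rather than methoxy, so the recovery may be incomplete. A rise of a number 40 percentage points higher from compound 2 to compound 3 (beyond the scatter) is therefore expected. Compound 3 is estimated at 65%, with a range from 25% to 95%, in this assay.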

Compound 3, a percentage reported as inhibition, at one concentration (the size of the read-out at that concentration, not a potency): 20%
Compound 3: middle estimate off by 45 percentage points, on the high side; the whole stated range lies above it.
By their numbers in this assay, from the lowest: compounds 3 and 2 (each within the scatter of the next); then compound 1.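

Putting an alkoxy group back on the carbonyl carbon is not enough to hold the number at this position: in this assay, (ethoxycarbonyl)(methyl)amino in place of (methoxycarbonyl)amino gives a number 75 percentage points lower from compound 1 to compound 3 (beyond the scatter) even though both groups carry an alkoxy group on the carbonyl. Replacing ((tert-butyl)carbonyl)amino with (ethoxycarbonyl)(methyl)amino exchanges a group with a hydrogen-bond donor for one without, yet it gives only a number 5 percentage points lower from compound 2 to compound 3 (within the scatter) and so shows that, between these two groups, losing the donor comes with no change beyond the scatter. No measurement at hand accounts for this result.

The step from compound 1 to compound 3 joins two changes, the methyl on the nitrogen and ethoxy in place of methoxy, and the compounds shown do not tell whether one of them or both together carry it. Also open, going by these compounds, is where (methoxycarbonyl)(methyl)amino or (ethoxycarbonyl)amino would fall, and whether a longer chain such as propoxy on the carbonyl carbon, or a free amine in this place, would stand nearer compound 1 or compound 3.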